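This account rests on a few compounds, and the source may have more. Where it says the series, first, only, none or still open, it means among the compounds named here.

Compound 3 `CC(=O)Nc1ccc(Cn2nc(Nc3cc(C)[nH]n3)c3ccccc3c2=O)cc1` carries an acetamido group on a six-membered aromatic ring of carbon only, hanging off the shared core. In a functional assay on MCF7 cells (Homo sapiens) for cytotoxicity (on this read-out higher numbers stand for weaker inhibition and lower numbers for stronger inhibition), compound 3 reaches only the assay limit, reported as > 30000 nM, not a measured number. Compound 2 `Cc1cc(Nc2nn(C)c(=O)c3ccccc23)n[nH]1`, which lacks that ring altogether, likewise gives only a limit, > 30000 nM. Compound 1 `Cc1cc(Nc2nn(Cc3ccc(S(C)(=O)=O)cc3)c(=O)c3ccccc23)n[nH]1` carries a methylsulfonyl group where compound 3 carries acetamido. In this assay, for the measured compounds named here, compound 1 gives 4500 nM, the one real number among the three. Compound 4 `Cc1cc(Nc2nn(Cc3ccc([N+](=O)[O-])cc3)c(=O)c3ccccc23)n[nH]1` is compound 3 with nitro in place of acetamido on an aromatic carbon. Going by the values given here, the only measured step touching this spot is an at least 6.6-fold higher number from compound 1 to compound 3 (0.82 log units; beyond the scatter), which shows that replacing acetamido can lower the number well past the scatter. For compound 4 the step of an at least 3.0-fold lower number from compound 3 to compound 4 (0.47 log units; beyond the scatter) is expected, giving an estimated 10000 nM with a range from 3000 nM to 30000 nM.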

Compound 4, half-maximal inhibitory concentration: > 30000 nM
Compound 4 ended at the assay's limit (the forecaster's own chance of this, stated with the estimate: 35%); middle value at least 3.0-fold (0.47 log units) from the limit.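

Nitro in place of methylsulfonyl gives an at least 6.6-fold higher number from compound 1 to compound 4 (0.82 log units; beyond the scatter), so acetamido is no longer the only group at this spot to fall short of compound 1. Among the compounds shown, only methylsulfonyl on this ring gives a real number in this assay. The steps from compound 3 to compound 4 and from compound 2 to compound 4 cannot be read, because both ends of each are limits: the limit of > 30000 nM in this assay, at which 3 of the 4 values shown sit.

As far as these compounds go, how far compound 2, compound 3 and compound 4 lie past that limit remains open. So does whether an amine or a carboxylic acid on this ring would give a real number.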